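The compounds below may be only part of what the source reports. "The series", "measured", "known", "first", "only" and "open" are said of these compounds alone.

Compound 1: `O=C(O)c1csc(-n2nc(-c3ccccc3)c3ccncc32)n1` — in an assay on isolated protein for antagonist activity at prostaglandin E2 receptor EP1 subtype (Homo sapiens), read by reporter gene assay (a lower number here means a stronger inhibitor, a higher number a weaker inhibitor), compound 1 gives 39 nM
Compound 2: `O=C(O)c1csc(-n2nc(-c3ccccc3)c3ccc(F)cc32)n1` — in this assay compound 2 gives 2 nM
Compound 3: `O=C(O)c1csc(-n2nc(-c3ccc(Cl)cc3)c3ccccc32)n1` — in this assay compound 3 gives 12 nM

Three compounds share a core in which a carboxy-thiazole hangs from a fused two-ring system, and an aryl group sits on the same five-membered ring. Among them, compound 3 stands second highest: its number in this assay lies below that of compound 1 and above that of compound 2, and both gaps are beyond the usual scatter. Compound 4, `O=C(O)c1csc(-n2nc(-c3cncnc3)c3ccccc32)n1`, has not yet been measured. It differs from compound 3 in one place: pyrimidin-5-yl in place of 4-chlorophenyl on an aromatic carbon. Going by the values given here, no measured pair shows this kind of swap, so the expected step rests only on the spread of the three numbers seen so far. The step from compound 3 to compound 4 is expected to be modest and towards a higher number, estimated as a 4.2-fold higher number from compound 3 to compound 4 (0.62 log units; beyond the scatter). Compound 4 is expected to give 50 nM in this assay, within a range from 10 nM to 300 nM.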

Compound 4, half-maximal inhibitory concentration: > 100 nM
Compound 4: a limit, no number; the forecaster's own chance of this, stated with the estimate: 5%; at least 2.0-fold (0.30 log units) between middle value and limit.
By their numbers in this assay, from the lowest: compound 2; then compound 3; then compound 1. At a limit, above all of these: compound 4.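

Placing pyrimidin-5-yl instead of 4-chlorophenyl on this aromatic carbon of the five-membered ring gives an at least 8.3-fold higher number from compound 3 to compound 4 (0.92 log units; beyond the scatter) in this assay, so exchanging one six-membered aromatic ring for another is far from neutral here. Compound 4 reads > 100 nM, which is a limit of the assay and not a number, and it is the only such reading among these compounds: the limit of > 100 nM in this assay, at which 1 of the 4 values shown sits. Compound 1, compound 2 and compound 3 all carry a ring of carbon only at this place, so compound 4 gives the first sign that a ring with hetero atoms here goes with much weaker inhibition.

The step removes the chlorine and brings in the ring nitrogens together, so the compounds shown cannot say which of the two matters. As far as these compounds go, how a pyridin-3-yl group on this carbon would read remains open.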